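A Ring Swap at the Aryl End of the Oxazole Ketone

This account rests on a few compounds, and the source may have more. Where it says the series, first, only, none or still open, it means among the compounds named here.

Three compounds share a core and differ only in the aryl group that hangs from it. In an assay (Rattus norvegicus) for inhibition of Fatty-acid amide hydrolase 1 (Homo sapiens) (on this read-out higher numbers stand for weaker inhibition and lower numbers for stronger inhibition), compound 1 `Nc1ccc(-c2cnc(C(=O)CCCCCCc3ccccc3)o2)cc1` gives 90 nM, the highest of the three numbers. Compound 2 `NS(=O)(=O)c1ccc(-c2cnc(C(=O)CCCCCCc3ccccc3)o2)cc1` gives 10 nM, and compound 3 `O=C(CCCCCCc1ccccc1)c1ncc(-c2ccc(C(=O)C(F)(F)F)cc2)o1` gives 65 nM. The step of a 1.4-fold lower number from compound 1 to compound 3 (0.14 log units; within the scatter) lies within the scatter, whereas a 9.0-fold lower number from compound 1 to compound 2 (0.95 log units; beyond the scatter) and a 6.5-fold higher number from compound 2 to compound 3 (0.81 log units; beyond the scatter) are modest but real shifts.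

Compound 4 `Cc1ccc(-c2cnc(C(=O)CCCCCCc3ccccc3)o2)nc1` is not yet measured. It differs from compound 1 in one place: 5-methylpyridin-2-yl in place of 4-aminophenyl on an aromatic carbon

Among the measured compounds shown here, every measured step swaps the group carried on the benzene ring, while this change replaces the ring itself, so none of the measured steps bears on it directly. The measured values span from compound 2 at 10 nM to compound 1 at 90 nM across such swaps, which sets the scale of what a single change at this position has done so far. For the measured compounds named here, with no direct precedent, the expected step of a 1.1-fold higher number from compound 1 to compound 4 (0.05 log units; within the scatter) is taken as small and uncertain, so compound 4 is estimated at 100 nM, with a range from 25 nM to 400 nM.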

Compound 4, inhibition constant: 2.8 nM
Beside the measured number, compound 4's estimate is 36-fold (1.55 log units) above it, outside the stated range (below it).
By their numbers in this assay, from the lowest: compound 4; then compound 2; then compounds 3 and 1 (each within the scatter of the next).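

The change of ring gives a 32-fold lower number from compound 1 to compound 4 (1.51 log units; beyond the scatter) in this assay, a larger shift than any swap of the group on the benzene ring, including a 9.0-fold lower number from compound 1 to compound 2 (0.95 log units; beyond the scatter). So this position on the core, next to the ring oxygen, responds more to the identity of the aromatic ring than the earlier compounds could show, and compound 4 now has the lowest number of the four. The step removes the amino group and brings in a ring nitrogen and a methyl all at once, and nothing measured here says why the number fell so far.

The compounds shown leave open how much of the step belongs to the ring nitrogen and how much to the methyl, which a plain pyridin-2-yl group would help to separate. They also leave open whether a sulfamoyl group on the pyridine ring would lower the number further.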